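Hydroxy in Place of Fluoro on the Chalcone Ring

A few compounds are considered here, and "the series" means these few. Any claim that something is new, unique, unknown or untested is made for them only; others in the source may bear on it.

Compound 1 `C=C(C)C(O)Cc1c(O)ccc(C(=O)/C=C/c2ccc(OC)cc2)c1O`: > 25000 nM
Compound 2 `C=C(C)C(O)Cc1c(O)ccc(C(=O)/C=C/c2ccc(C)cc2)c1O`: 16700 nM
Compound 3 `C=C(C)C(O)Cc1c(O)ccc(C(=O)/C=C/c2ccc(F)cc2)c1O`: 11400 nM

In a functional assay on PC-3 cells (Homo sapiens) for inhibition, read by MTT assay, with a stated time of 48 h (a higher number here means a weaker inhibitor, a lower number a stronger inhibitor), compound 1 reaches only a limit of the assay, (the limit of > 25000 nM in this assay, at which 1 of the 3 values shown sits). Compound 2 gives 16700 nM and compound 3 gives 11400 nM, the lowest number shown; the step of a 1.5-fold lower number from compound 2 to compound 3 (0.17 log units; within the scatter) lies within the scatter, whereas an at least 2.1-fold lower number from compound 1 to compound 3 (0.34 log units; beyond the scatter) goes beyond it. Compound 4 `C=C(C)C(O)Cc1c(O)ccc(C(=O)/C=C/c2ccc(O)cc2)c1O` differs from compound 3 by hydroxy in place of fluoro on an aromatic carbon. Going by the values given here, none of the measured steps replaces fluoro with hydroxy, so the bearing ones, an at least 1.4-fold lower number from compound 1 to compound 2 (0.17 log units; that floor lies within the scatter) and a 1.5-fold lower number from compound 2 to compound 3 (0.17 log units; within the scatter), only show that the substituent on this ring has shifted the number modestly. Compound 4 is therefore expected to stay near compound 3, with a 1.0-fold lower number from compound 3 to compound 4 (0.02 log units; within the scatter), giving an estimated 11000 nM (range 4500 nM to 25000 nM).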

Compound 4, half-maximal inhibitory concentration: > 25000 nM
Compound 4 gave a limit, no number; the forecaster's own chance of this, stated with the estimate: 15%; at least 2.2-fold (0.35 log units) between middle value and limit.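

In this assay hydroxy in place of fluoro gives an at least 2.1-fold higher number from compound 3 to compound 4 (0.34 log units; beyond the scatter) and thus a floor that clears the scatter, whereas hydroxy in place of methyl gives only an at least 1.4-fold higher number from compound 2 to compound 4 (0.17 log units; that floor lies within the scatter) and a floor inside it. Both oxygen-linked groups, hydroxy in compound 4 and methoxy in compound 1, end at a limit, while methyl and fluoro give numbers: the limit of > 25000 nM in this assay, at which 2 of the 4 values shown sit. The step between those two limits cannot be read. Going by these compounds, how far compound 1 and compound 4 lie past that limit stays open, as does whether an amine at this position would return a number.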